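Chloro on the pendant phenyl of compound 2

A few compounds are considered here, and "the series" means these few. Any claim that something is new, unique, unknown or untested is made for them only; others in the source may bear on it.

Among the measured compounds shown here, compound 2 `Cc1cc(-c2ccccc2)cc(C)c1Nc1ccnc(Nc2ccc(C#N)cc2)n1` gives 4170 nM in an ADME assay on MT4 cells (Homo sapiens) for cytotoxicity, read by MTT assay, with a stated time of 4 days (a lower number here means that less compound is tolerated, a higher number that more compound is tolerated), the highest of the three numbers so far; compound 1 `COc1ccc(-c2cc(C)c(Nc3ccnc(Nc4ccc(C#N)cc4)n3)c(C)c2)cc1` gives 2890 nM, and compound 3 `Cc1cc(-c2cccc(C#N)c2)cc(C)c1Nc1ccnc(Nc2ccc(C#N)cc2)n1` gives 920 nM. The step of a 1.4-fold higher number from compound 1 to compound 2 (0.16 log units; within the scatter) stays within the scatter, whereas a 4.5-fold lower number from compound 2 to compound 3 (0.66 log units; beyond the scatter) and a 3.1-fold lower number from compound 1 to compound 3 (0.50 log units; beyond the scatter) go beyond it. Compound 4 `Cc1cc(-c2cccc(Cl)c2)cc(C)c1Nc1ccnc(Nc2ccc(C#N)cc2)n1` differs from compound 2 by chloro in place of hydrogen on an aromatic carbon, entering at the place where compound 3 carries its cyano. The step of a 4.5-fold lower number from compound 2 to compound 3 (0.66 log units; beyond the scatter) is the one that bears on this change; a single chlorine is a different group from a nitrile, so a smaller shift is anticipated. Compound 4 is expected to give 2000 nM in this assay, between 800 nM and 5000 nM, an expected modest lowering of a 2.1-fold lower number from compound 2 to compound 4 (0.32 log units; beyond the scatter).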

Compound 4, half-maximal cytotoxic concentration: 2160 nM
Compound 4: middle estimate off by 1.1-fold (0.03 log units), on the low side; measured number inside the range.
By their numbers in this assay, from the lowest: compound 3; then compounds 4, 1 and 2 (each within the scatter of the next).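

At this place on the pendant phenyl, chloro is not separated from hydrogen (a 1.9-fold lower number from compound 2 to compound 4 (0.29 log units; within the scatter)), so the lowering seen with the nitrile does not extend to every substituent tried here. Exchanging the nitrile for chloro gives a step beyond the scatter (a 2.3-fold higher number from compound 3 to compound 4 (0.37 log units; beyond the scatter)), which separates the two groups at this one position. The change from 4-methoxyphenyl to 3-chlorophenyl also remains unresolved (a 1.3-fold lower number from compound 1 to compound 4 (0.13 log units; within the scatter)).

From the compounds shown here alone, whether an amine or a carboxylic acid at this place would shift the number remains open. Nothing available accounts for the difference between chloro and the nitrile.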